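A few compounds are considered here, and "the series" means these few. Any claim that something is new, unique, unknown or untested is made for them only; others in the source may bear on it.

Measured compounds:
compound 1, `C=CCc1cc(-c2cccc([N+](=O)[O-])c2)ccc1O`: > 100000 nM
compound 2, `C=CCc1cc(-c2ccc(OC)cc2)ccc1O`: > 100000 nM

Of the compounds shown here, two have been tested so far in a functional assay on A549 cells (Homo sapiens) for antiproliferative activity, read by MTT assay, with a stated time of 24 h; a lower number here means a stronger inhibitor, a higher number a weaker inhibitor. For compound 1 the value > 100000 nM is a limit of the assay rather than a number. For compound 2 the value > 100000 nM is likewise a limit, not a number. Compound 2 therefore stands at the edge of what this assay can report, and the same is true of the other compound shown: the limit of > 100000 nM in this assay, at which 2 of the 2 values shown sit.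

Compound 3 `C=CCc1cc(-c2ccccc2)ccc1O` has not yet been measured in this assay. It differs from compound 2 in a single place: hydrogen in place of methoxy on an aromatic carbon. Among the compounds with values here, no step between measured compounds is available to guide the expectation, since both values shown are limits. The expected step from compound 2 to compound 3 is a number no higher from compound 2 to compound 3 (the limit leaves the size open), that is, none beyond the scatter. Compound 3 is expected to sit at about 100000 nM in this assay, between 30000 nM and 300000 nM, and it is thought likely that only a limit will again be reported.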

Compound 3, half-maximal inhibitory concentration: > 100000 nM
Compound 3: a limit, no number; the forecaster's own chance of this, stated with the estimate: 80%; the middle value sits exactly at the limit.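

Compound 3 joins compound 1 and compound 2 at the edge of this assay, so no step from compound 2 or compound 1 to compound 3 can be read, because every value is a limit: the limit of > 100000 nM in this assay, at which 3 of the 3 values shown sit.

The compounds shown leave open how strongly any of them acts in this assay and whether exchanging hydrogen, methoxy or nitro changes that activity.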